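Cytotoxicity of aryl piperazine ketones on Vero cells

A few compounds are considered here, and "the series" means these few. Any claim that something is new, unique, unknown or untested is made for them only; others in the source may bear on it.

Measured so far:
compound 1 `O=C(CCN1CCN(c2ccc(F)cc2)CC1)c1ccccc1` — 13400 nM
compound 2 `O=C(CCN1CCN(c2ccc(C(F)(F)F)cc2)CC1)c1ccccc1` — 15700 nM
compound 3 `COc1ccc(C(=O)CCN2CCN(c3ccc(F)cc3)CC2)cc1OC` — 175000 nM

Of the compounds shown here, three have been tested in an ADME assay on Vero cells (Chlorocebus sabaeus) for cytotoxicity, read by resazurin assay, with a stated time of 72 h; a lower number here means a stronger inhibitor, a higher number a weaker inhibitor. Compound 1 `O=C(CCN1CCN(c2ccc(F)cc2)CC1)c1ccccc1` gives 13400 nM in this assay, and compound 2 `O=C(CCN1CCN(c2ccc(C(F)(F)F)cc2)CC1)c1ccccc1` gives 15700 nM. The pair differs in one place, (trifluoromethyl in place of fluoro on an aromatic carbon), and the step of a 1.2-fold higher number from compound 1 to compound 2 (0.07 log units; within the scatter) is small. Compound 3 `COc1ccc(C(=O)CCN2CCN(c3ccc(F)cc3)CC2)cc1OC` gives 175000 nM in this assay, the highest of the three numbers, and its gap to both compound 1 and compound 2 lies beyond the scatter. How the core of compound 3 differs from the core of compound 1 is not broken down here.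

Compound 4 `COc1ccc(C(=O)CCN2CCN(c3ccc(C(F)(F)F)cc3)CC2)cc1OC` has not yet been measured. It stands to compound 3 as compound 2 stands to compound 1: trifluoromethyl in place of fluoro on an aromatic carbon. The place of the change is the same in both pairs, so this is the same kind of change made on a different core. Because the measured step of a 1.2-fold higher number from compound 1 to compound 2 (0.07 log units; within the scatter) lay within the scatter, the step of a 1.1-fold higher number from compound 3 to compound 4 (0.06 log units; within the scatter) is expected to be of similar size. On that basis compound 4 is estimated to give 200000 nM in this assay, with a likely range from 90000 nM to 450000 nM.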

Compound 4, half-maximal inhibitory concentration: 243000 nM
The estimate for compound 4 lay 1.2-fold (0.08 log units) below the measured number; low and high end bracket the measured number.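

In this assay, trifluoromethyl in place of fluoro on an aromatic carbon behaved alike on the two cores, the gap between the two steps being no larger than repeated measurements would give: the same change on two cores in this assay, a 1.2-fold higher number (0.07 log units; within the scatter) from compound 1 to compound 2 and a 1.4-fold higher number (0.14 log units; within the scatter) from compound 3 to compound 4, 1.2-fold (0.07 log units) apart, within the scatter of two such steps On the second core the change gave a 1.4-fold higher number from compound 3 to compound 4 (0.14 log units; within the scatter), so on neither core can the two numbers of a pair be told apart, whereas 3,4-dimethoxyphenyl in place of phenyl on a carbonyl carbon, with trifluoromethyl kept, gave a 15-fold higher number from compound 2 to compound 4 (1.19 log units; beyond the scatter). This shows that the change carried over between these two cores in this one assay, but two pairs do not show that it would carry over to any other core, and they give no reason for the result.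

The compounds shown leave open whether other groups on that aromatic carbon, such as a nitrile, a carboxylic acid or an amine, would also leave the number in place on both cores. They also leave open which part of 3,4-dimethoxyphenyl goes with the large step, since a phenyl carrying a single methoxy group does not appear among them, and whether a longer chain at the ketone would alter the picture.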